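This account rests on a few compounds, and the source may have more. Where it says the series, first, only, none or still open, it means among the compounds named here.

Measured compounds: compound 1 `Cc1c(CCC(=O)O)cccc1NC(=O)[C@H](c1ccc(Cl)cc1)C1CCCC1`, compound 2 `C[C@H]([C@H](C(=O)Nc1cccc(CC2(C(=O)O)CC2)c1)c1ccc(Cl)cc1)C(F)(F)F` and compound 3 `C[C@H]([C@H](C(=O)Nc1cc(CC2(C(=O)O)CC2)ccc1Cl)c1ccc(Cl)cc1)C(F)(F)F`.

In an assay on CHO cells for activation of Guanylate cyclase soluble subunit alpha-1 (Rattus norvegicus), read by luminescence and cGMP accumulation, with a stated time of 6 min (a higher number here means a larger maximal response, a lower number a smaller maximal response), compound 1 gives 19%, compound 2 gives 4% and compound 3 gives 63%, the highest of the three. Among the measured compounds shown here, the one single-change step in this assay is a number 59 percentage points higher from compound 2 to compound 3 (beyond the scatter), so chloro at that carbon is tied to the largest number seen.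

Compound 4 `Cc1ccc(CC2(C(=O)O)CC2)cc1NC(=O)[C@H](c1ccc(Cl)cc1)[C@@H](C)C(F)(F)F` differs from compound 3 by methyl in place of chloro on an aromatic carbon. For the measured compounds named here, only that one step bears on this change, and it says nothing directly about methyl. Since methyl is not hydrogen, compound 4 is expected to keep part of the response of compound 3, with a moderate step downward a number 23 percentage points lower from compound 3 to compound 4 (beyond the scatter) in this assay. Compound 4 is therefore estimated at 40%, within 15% to 65%.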

Compound 4, largest response reached (reported as efficacy), in percent of the reference or control that the assay uses: 44%
Compound 4: the middle estimate sits 4 percentage points below what was measured; the measured number falls inside the stated range.
By their numbers in this assay, from the lowest: compound 2; then compound 1; then compound 4; then compound 3.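

In this assay, the gain at the carbon para to the (1-carboxycyclopropyl)methyl group is not specific to chloro: methyl in place of hydrogen there brings a number 40 percentage points higher from compound 2 to compound 4 (beyond the scatter) and so recovers much of the response without a halogen. Chloro still holds an edge, as methyl in place of chloro brings a number 19 percentage points lower from compound 3 to compound 4 (beyond the scatter). No evidence here bears on why either group raises the response. Going by these compounds, whether a fluoro, methoxy or ethyl group at this carbon would match chloro or methyl remains open. So does whether a nitrile would support any gain there at all.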